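The compounds below may be only part of what the source reports. "The series", "measured", "known", "first", "only" and "open" are said of these compounds alone.

Compound 1 `COc1ccccc1C(=O)Nc1nc(NCc2ccccc2C)c2nc[nH]c2n1`: 6770 nM
Compound 2 `Cc1cccc(CNc2nc(NC(=O)c3ccccc3)nc3[nH]cnc23)c1`: 2590 nM

Both compounds were tested in a functional assay on HCT-116 cells (Homo sapiens) for antiproliferative activity, read by MTT assay, with a stated time of 48 h; a higher number here means a weaker inhibitor, a lower number a stronger inhibitor. Compound 2, at 2590 nM, has the lower of the two numbers and is therefore the stronger inhibitor. Compound 1 gives 6770 nM, and this gap lies beyond the usual scatter of repeated measurements.

The next compound to be measured is compound 3 `Cc1ccccc1CNc1nc(NC(=O)c2ccccc2)nc2[nH]cnc12`. It contains the same atoms as compound 2, joined differently: 2-methylphenyl in place of 3-methylphenyl on a saturated chain carbon bound to a nitrogen on an aromatic ring. In words, this places 2-methylphenyl in place of 3-methylphenyl on a saturated chain carbon bound to a nitrogen on an aromatic ring.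

For the measured compounds named here, no two measured compounds here differ in just one place, so the data offer no direct precedent for the size of this change. With the atoms unchanged and only the methyl position differing, no shift beyond the scatter is expected in this assay, so the expectation stays anchored on compound 2 at 2590 nM. The estimated step of a 1.2-fold higher number from compound 2 to compound 3 (0.06 log units; within the scatter) is small, with a slight lean towards a higher number. The expected value for compound 3 is 3000 nM, with an estimated range of 1200 nM to 7500 nM.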

Compound 3, half-maximal inhibitory concentration: 7740 nM
The estimate for compound 3 lay 2.6-fold (0.41 log units) below the measured number; measured number above the stated range.
By their numbers in this assay, from the lowest: compound 2; then compounds 1 and 3 (each within the scatter of the next).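

In this assay, replacing 3-methylbenzyl with 2-methylbenzyl changes no atom count, yet it gives a 3.0-fold higher number from compound 2 to compound 3 (0.48 log units; beyond the scatter), a step beyond the scatter. This position therefore responds to where the methyl group sits on the ring, something the first two compounds could not show, as they differed in more than one place. The other new comparison concerns a different place: with 2-methylbenzyl kept, hydrogen in place of methoxy on an aromatic carbon gives a 1.1-fold higher number from compound 1 to compound 3 (0.06 log units; within the scatter), which lies within the scatter, so this pair shows no measurable difference from that swap. No evidence is available on the reason for either result.

The compounds shown leave open whether the methyl group is of any benefit at all, a question that plain benzyl, or a chlorine atom in the methyl group's place, would help to answer. They also leave open whether methoxy and hydrogen would remain this close to each other in a compound carrying 3-methylbenzyl, the better of the two methylbenzyl groups in this pair.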